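The compounds below may be only part of what the source reports. "The series", "measured", "known", "first", "only" and "open" are said of these compounds alone.

Measured compounds:
- compound 1 `COc1ncc(-c2ccc3nccc(-c4ccc(C)cc4)c3c2)cc1NS(=O)(=O)c1ccc(F)cc1F` — 2540 nM
- compound 2 `COc1ncc(-c2ccc3nccc(-c4ccc(CN5CCCCC5)cc4)c3c2)cc1NS(=O)(=O)c1ccc(F)cc1F` — 34.1 nM
- compound 3 `COc1ncc(-c2ccc3nccc(-c4ccc(Cn5cncn5)cc4)c3c2)cc1NS(=O)(=O)c1ccc(F)cc1F` — 8.7 nM

In a functional assay on HCT-116 cells (Homo sapiens) for cytotoxicity, read by MTT assay, with a stated time of 72 h (on this read-out higher numbers stand for weaker inhibition and lower numbers for stronger inhibition), compound 1 gives 2540 nM, the highest number of the three; compound 2 at 34.1 nM and compound 3 at 8.7 nM both sit well beyond the scatter from it. The unmeasured compound 4 `COc1ncc(-c2ccc3nccc(-c4ccc(Cn5ccnc5)cc4)c3c2)cc1NS(=O)(=O)c1ccc(F)cc1F` is reached from compound 1 by this change: 1H-imidazol-1-yl in place of hydrogen on a saturated chain carbon bound to an aromatic carbon.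

Two measured steps start from the same hydrogen at the same place. The step of a 74-fold lower number from compound 1 to compound 2 (1.87 log units; beyond the scatter) and the step of a 290-fold lower number from compound 1 to compound 3 (2.47 log units; beyond the scatter) were both large drops in the number. Between the two replacements the step of a 3.9-fold lower number from compound 2 to compound 3 (0.59 log units; beyond the scatter) was modest, so the ring that enters in compound 3 gave the lower number of the two. Within the data shown here, the group entering in compound 4 is, like the one in compound 3, a five-membered aromatic ring with two nitrogen atoms attached through ring nitrogen, whereas compound 2 carries a saturated ring; no measured compound carries the imidazole itself.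

On that basis a large drop is expected in this assay, a 170-fold lower number from compound 1 to compound 4 (2.23 log units; beyond the scatter), with compound 4 most likely landing between the numbers of compound 2 and compound 3 or near the latter. Compound 4 is estimated at 15 nM, within 5 nM to 60 nM.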

Compound 4, half-maximal inhibitory concentration: 32.6 nM
Compound 4: middle estimate off by 2.2-fold (0.34 log units), on the low side; the range from low to high includes it.
By their numbers in this assay, from the lowest: compound 3; then compounds 4 and 2 (each within the scatter of the next); then compound 1.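

In this assay, 1H-imidazol-1-yl on the saturated chain carbon bound to an aromatic carbon also gives a large drop from hydrogen (a 78-fold lower number from compound 1 to compound 4 (1.89 log units; beyond the scatter)), so the drop now holds for all three rings placed on this carbon. The two five-membered aromatic rings are not interchangeable at this position: 1H-imidazol-1-yl in place of 1H-1,2,4-triazol-1-yl gives a modest but real rise (a 3.7-fold higher number from compound 3 to compound 4 (0.57 log units; beyond the scatter)), whereas 1H-imidazol-1-yl and piperidin-1-yl cannot be told apart (a 1.0-fold lower number from compound 2 to compound 4 (0.02 log units; within the scatter)), so sorting the rings into aromatic and saturated does not sort the values in these compounds. Nothing at hand accounts for these differences between the rings.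

Open, as far as these compounds go, is whether the drop needs a ring at all, or whether an open-chain dimethylamino group or a carboxylic acid on the same carbon would also give it. Also open, from the compounds shown here alone, is whether 1H-1,2,4-triazol-1-yl keeps the low value of compound 3 (8.7 nM) when carried on a longer chain, and whether a morpholin-4-yl ring behaves like piperidin-1-yl.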